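The source may report more compounds than this note shows. Statements on the series, on what has been measured and on what is new or still open speak of the compounds shown alone.

In a functional assay on KB-V1 cells (Homo sapiens) for cytotoxicity, read by MTT assay, with a stated time of 72 h (on this read-out higher numbers stand for weaker inhibition and lower numbers for stronger inhibition), compound 1 (`O=C1Nc2ccccc2/C1=N/NC(=S)Nc1cccc2ccccc12`) gives 2210 nM, compound 2 (`O=C1Nc2ccccc2/C1=N/NC(=S)Nc1ccc2c(c1)CCC2`) gives 2850 nM and compound 3 (`O=C1Nc2ccccc2/C1=N/NC(=S)NC1CCCCC1`) gives 4380 nM. Compound 3 thus stands within the usual scatter of both other compounds, so these three numbers cannot be put in a reliable order.

Compound 4 (`O=C1Nc2ccccc2/C1=N/NC(=S)Nc1cccc(Cl)c1`) keeps the shared core but has 3-chlorophenyl in place of cyclohexyl on an amide-type nitrogen. Going by the values given here, no measured pair shows this exact kind of change, so the expectation has to rest on the nearest compounds. Compound 1 and compound 2 also hold an aromatic ring on that nitrogen, yet neither differs from compound 3 beyond the scatter.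

A small shift in this assay toward a lower number is therefore expected, probably no larger than the scatter. The estimated change is a 1.6-fold lower number from compound 3 to compound 4 (0.21 log units; within the scatter). For compound 4 the expected value is 2700 nM, with an estimated range from 1000 nM to 6500 nM.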

Compound 4, half-maximal inhibitory concentration: 640 nM
Compound 4: the middle estimate sits 4.2-fold (0.63 log units) above what was measured, and the stated range ends above it.
By their numbers in this assay, from the lowest: compound 4; then compounds 1, 2 and 3 (each within the scatter of the next).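

Placing 3-chlorophenyl in place of cyclohexyl on the amide-type nitrogen, whose other neighbour is the thiocarbonyl carbon, gives a step beyond the scatter in this assay: a 6.8-fold lower number from compound 3 to compound 4 (0.84 log units; beyond the scatter). This shows that a change at this position can move the number by more than repeat measurements would, which compound 1, compound 2 and compound 3 could not show, as their numbers lie within the scatter of one another. No measurement shown here explains the size of this step.

Still open, from the compounds shown here alone, is how much of the step belongs to the chlorine and how much to the aromatic ring, which a plain phenyl group on the same nitrogen would help to separate. Also open, going by these compounds, is whether a carboxylic acid or an amine on that ring, or a longer alkyl chain on that nitrogen, would shift the number in the same direction.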